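This account rests on a few compounds, and the source may have more. Where it says the series, first, only, none or still open, it means among the compounds named here.

Measured compounds:
compound 1 `O=C(Nc1nc2ccc(Cl)cc2s1)c1cc(-c2ccc(F)cc2)n2nc(-c3ccccc3)cc2n1` — 19800 nM
compound 2 `O=C(Nc1nc2ccc(F)cc2s1)c1cc(-c2ccc(F)cc2)n2nc(-c3ccccc3)cc2n1` — 22900 nM
compound 3 `Cc1cc2nc(NC(=O)c3cc(-c4ccc(F)cc4)n4nc(-c5ccccc5)cc4n3)sc2cc1C` — 17000 nM

All three values come from a functional assay on MCF7 cells (Homo sapiens) for cytotoxicity, read by MTT assay, with a stated time of 48 h; on this read-out lower numbers stand for stronger inhibition and higher numbers for weaker inhibition. Compound 3 carries the lowest number of the three, but its gaps to the others are small: a 1.2-fold lower number from compound 1 to compound 3 (0.07 log units; within the scatter) and a 1.3-fold lower number from compound 2 to compound 3 (0.13 log units; within the scatter), both within the scatter, so the three compounds cannot be told apart on cytotoxicity. The same holds for the remaining pair, a 1.2-fold higher number from compound 1 to compound 2 (0.06 log units; within the scatter).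

The step to compound 4 `COc1cc(-c2cc(C(=O)Nc3nc4cc(C)c(C)cc4s3)nc3cc(-c4ccccc4)nn23)cc(OC)c1OC` changes a different part of the shared core than any measured step: 3,4,5-trimethoxyphenyl in place of 4-fluorophenyl on an aromatic carbon. Every measured step alters the group on the amide-type nitrogen; none touches the aryl group on the aromatic carbon of the two-ring system. Within the data shown here, there is therefore no measured step that bears directly on this change, and the series so far only shows that this assay reads the three analogues at closely similar numbers.

Among the measured compounds shown here, with no guiding step, a cautious estimate is a number near compound 3 with a wide range, and a slight lean toward a lower number is no more than a guess. For compound 4 the estimate in this assay is 12000 nM (range 4000 nM to 40000 nM), which would mean a step of a 1.4-fold lower number from compound 3 to compound 4 (0.15 log units; within the scatter).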

Compound 4, half-maximal inhibitory concentration: 2290 nM
For compound 4 the middle estimate is 5.2-fold (0.72 log units) above the measured one; the whole stated range lies above it.
By their numbers in this assay, from the lowest: compound 4; then compounds 3, 1 and 2 (each within the scatter of the next).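

Among these compounds, replacing 4-fluorophenyl with 3,4,5-trimethoxyphenyl on the aromatic carbon next to the ring nitrogen gives a 7.4-fold lower number from compound 3 to compound 4 (0.87 log units; beyond the scatter) in this assay and is the only step that lies beyond the scatter. The steps among compounds 1, 2 and 3 all alter the group on the amide-type nitrogen and all stay within the scatter, so this aryl position is the first place shown to move the number in this assay. That reading rests on a single pair, with 5,6-dimethyl-1,3-benzothiazol-2-yl held constant on the amide-type nitrogen, and nothing available gives a measured reason for the step.

Going by these compounds, it remains open whether the whole 3,4,5-trimethoxyphenyl group is needed at this position, or whether a plain phenyl, a phenyl with a single methoxy group or a phenyl with a dimethylamino group would give a similar number. Also open, on these data alone, is whether the same replacement gives a step of similar size when 6-chloro-1,3-benzothiazol-2-yl or 6-fluoro-1,3-benzothiazol-2-yl sits on the amide-type nitrogen.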